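Trifluoromethoxy for fluoro on the sulfur-linked aryl group

The source may hold more compounds than are shown below. What is called first, only, known or untested is meant among the compounds shown, and "the series" means these compounds.

In a functional assay on VCaP cells (Homo sapiens) for antiproliferative activity, read by propidium iodide staining, with a stated time of 96 h (on this read-out lower numbers stand for stronger inhibition and higher numbers for weaker inhibition), compound 1 (`CC(O)(CSc1ccc(F)cc1)C(=O)Nc1ccc(S(F)(F)(F)(F)F)cc1`) gives 23000 nM and compound 2 (`CC(O)(CSc1ccccc1C(F)(F)F)C(=O)Nc1ccc(S(F)(F)(F)(F)F)cc1`) gives 21000 nM with no separation beyond the scatter. Compound 1 therefore has no distinct rank on the two numbers available, and both compounds sit in the same range.

Compound 3 (`CC(O)(CSc1ccc(OC(F)(F)F)cc1)C(=O)Nc1ccc(S(F)(F)(F)(F)F)cc1`) keeps the core of compound 1 and carries trifluoromethoxy in place of fluoro on an aromatic carbon, para to a large group (trifluoromethoxy in place of fluoro on an aromatic carbon).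

For the measured compounds named here, only one measured step bears on this change (a 1.1-fold lower number from compound 1 to compound 2 (0.04 log units; within the scatter)) and it lies within the scatter. That step puts 2-(trifluoromethyl)phenyl in place of 4-fluorophenyl on a sulfur, so it is a different substitution and only an indirect guide. Going by the values given here, no measured compound carries trifluoromethoxy.

In this assay no step beyond the scatter is therefore expected, and no firm direction can be assigned. The estimated step (a 1.3-fold lower number from compound 1 to compound 3 (0.11 log units; within the scatter)) is accordingly small.

Compound 3 is expected at 18000 nM with an estimated range of 7000 nM to 40000 nM in the coming measurement.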

Compound 3, half-maximal inhibitory concentration: 16000 nM
Compound 3: middle estimate off by 1.1-fold (0.05 log units), on the high side, and the stated range covers the measured number.
By their numbers in this assay, from the lowest: compounds 3, 2 and 1 (each within the scatter of the next).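

At the aromatic carbon para to a large group, trifluoromethoxy in place of fluoro gives no separation beyond the scatter in this assay (a 1.4-fold lower number from compound 1 to compound 3 (0.16 log units; within the scatter)). Unlike the earlier step, which changed the substitution on the sulfur-linked aryl group in a different way, this comparison keeps the place of the group fixed and changes only the group. The larger trifluoromethoxy, which also brings a hydrogen-bond acceptor where fluoro has none by the computed count, is therefore tolerated at this place without a readable change, and the series remains in the same range; no measured evidence accounts for this result or links it to a property of either group.

The compounds shown leave open whether any group at this place can move the number beyond the scatter, since fluoro and trifluoromethoxy alone do not define a trend, and an amine or a carboxylic acid there would test a different kind of substituent. Also open, going by these compounds, is whether a sulfonyl in place of the sulfur link would separate from compound 1 in this assay, given that the aryl changes seen so far produce no such separation.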